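This account rests on a few compounds, and the source may have more. Where it says the series, first, only, none or still open, it means among the compounds named here.

Measured compounds:
- compound 1 `COc1cc2nc(-c3ccc(C(F)(F)F)cc3)cc(OCCCN3CCCCC3)c2cc1OC`: 651 nM
- compound 2 `COc1cc2nc(-c3ccc(Cl)cc3)cc(OCCCN3CCCCC3)c2cc1OC`: 838 nM

Both compounds were tested in a functional assay on IGROV-1 cells (Homo sapiens) for inhibition, read by sulforhodamine B assay, with a stated time of 48 h; a lower number here means a stronger inhibitor of growth, a higher number a weaker inhibitor of growth. Compound 1 gives 651 nM, which is the lowest of the two numbers, while compound 2 gives 838 nM. The only difference between them is chloro in place of trifluoromethyl on an aromatic carbon, and the step of a 1.3-fold higher number from compound 1 to compound 2 (0.11 log units; within the scatter) lies within the scatter, so the two values are not distinguishable.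

Compound 3 `COc1cc2nc(-c3ccc(C(F)(F)F)cc3)cc(OCCCN3CCCC3)c2cc1OC` has not yet been measured. It differs from compound 1 as follows: pyrrolidin-1-yl in place of piperidin-1-yl on a saturated chain carbon, three bonds along the chain from an oxygen on an aromatic ring. Within the data shown here, the one measured step changes a different part of the molecule, the group on the aromatic carbon, and so gives no direct guidance on shrinking the ring at the end of the chain. With nothing to indicate a shift in either direction, the step of a 1.1-fold higher number from compound 1 to compound 3 (0.03 log units; within the scatter) is expected to stay within the scatter. Compound 3 is therefore estimated at 700 nM, with a likely range from 300 nM to 1600 nM in this assay.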

Compound 3, concentration for 50% growth inhibition: 592 nM
Beside the measured number, compound 3's estimate is 1.2-fold (0.07 log units) above it; the measured number falls inside the stated range.
By their numbers in this assay, from the lowest: compounds 3, 1 and 2 (each within the scatter of the next).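

In this assay, pyrrolidin-1-yl in place of piperidin-1-yl gives a 1.1-fold lower number from compound 1 to compound 3 (0.04 log units; within the scatter), so the five-membered ring and the six-membered ring at the end of the chain cannot be told apart by this measure. Among these compounds, the earlier pair spoke only to the group on an aromatic carbon, whereas this pair gives the first reading at the far end of the chain, and within this pair the size of the ring there makes no detectable difference to growth inhibition. Nothing measured alongside these numbers speaks to what lies behind this result.

The two rings compared are close relatives, both saturated and each with a single nitrogen as its only hetero atom, so the shown compounds leave open whether a more different end group, such as morpholin-4-yl with its added ring oxygen or an open dimethylamino group, would also leave the number in place. Also open, as far as these compounds go, are whether a longer chain leading to the pyrrolidin-1-yl ring would matter and whether the same ring swap reads the same when chloro replaces trifluoromethyl on the aromatic carbon.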